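This account rests on a few compounds, and the source may have more. Where it says the series, first, only, none or still open, it means among the compounds named here.

Compound 1, `CN(C[C@H]1Cc2c(cccc2N2CCN(c3cccc(C(F)(F)F)c3)CC2)CN1)[C@H]1CCCc2cccnc21`: > 30000 nM
Compound 2, `CC(C)N(C[C@H]1Cc2c(cccc2N2CCNCC2)CN1)[C@H]1CCCc2cccnc21`: > 30000 nM

Of the compounds shown here, two have been tested in a functional assay on CCRF-CEM cells for agonist activity at C-X-C chemokine receptor type 4 (Homo sapiens), read by calcium flux, with a stated time of 25 min; on this read-out lower numbers stand for an effect already at smaller amounts and higher numbers for an effect only at larger amounts of compound. Compound 1 gives > 30000 nM in this assay, which is a limit of the assay rather than a number. Compound 2 likewise gives > 30000 nM in this assay, again a limit and not a number. Within the data shown here, compound 2 thus stands at the edge of what this assay can report, and it shares that position with the only other value shown: the limit of > 30000 nM in this assay, at which 2 of the 2 values shown sit. Among the measured compounds shown here, no step between measured compounds that differ in a single place is available from these two.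

Compound 3, `CN(C[C@H]1Cc2c(cccc2N2CCNCC2)CN1)[C@H]1CCCc2cccnc21`, has not yet been measured in this assay. It differs from compound 2 by methyl in place of isopropyl on an amine nitrogen. For the measured compounds named here, with both measured compounds sitting at the limit, there is no measured step from which to gauge the size of this change, so no shift beyond the usual scatter is expected in this assay. Compound 3 is therefore expected to give 30000 nM in this assay, within a range of 10000 nM to 100000 nM, and most likely again reported as a limit rather than a number. This estimate amounts to a step of a number no higher from compound 2 to compound 3 (the limit leaves the size open), expected to stay within the scatter.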

Compound 3, half-maximal effective concentration: > 30000 nM
Compound 3: a limit, no number (the forecaster's own chance of this, stated with the estimate: 85%); the middle value lies on the limit itself.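

Compound 3 adds no readable step: its comparisons with compound 2 and with compound 1 each set one limit against another, so neither size can be read. The compounds shown leave open whether any compound of this series reaches a number in this assay, since all of them stand at the same point: the limit of > 30000 nM in this assay, at which 3 of the 3 values shown sit.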